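The source may hold more compounds than are shown below. What is called first, only, known or untested is meant among the compounds shown, and "the series" means these compounds.

Of the compounds shown here, two built on one shared core have been tested so far in a functional assay on HGC-27 cells (Homo sapiens) for cytotoxicity, read by MTT assay, with a stated time of 72 h; a lower number here means a stronger inhibitor, a higher number a weaker inhibitor. Compound 1 `CCCCCCCCNc1nc(SCc2ccc(C(F)(F)F)cc2)nc2ccccc12` gives 13400 nM. Among the measured compounds shown here, compound 2 `FC(F)(F)c1ccc(CSc2nc(Nc3cccc(Cl)c3)c3ccccc3n2)cc1` gives 19900 nM, which is the larger of the two numbers, with compound 1 as its only neighbour; the one measured step, a 1.5-fold higher number from compound 1 to compound 2 (0.17 log units; within the scatter), lies within the scatter, so the two compounds cannot be told apart on potency.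

Compound 3 `O=[N+]([O-])c1ccc(Nc2nc(SCc3ccc(C(F)(F)F)cc3)nc3ccccc23)cc1` has not yet been measured. It differs from compound 2 by 4-nitrophenyl in place of 3-chlorophenyl on a nitrogen on an aromatic ring. For the measured compounds named here, no measured step exchanges one substituted phenyl for another on that nitrogen; the only step known, from an octyl chain to 3-chlorophenyl, stayed within the scatter. There is therefore no ground in the numbers to expect a shift in this assay beyond the scatter in either direction, and the expected step is a 1.0-fold higher number from compound 2 to compound 3 (0.00 log units; within the scatter). Compound 3 is estimated at 20000 nM, with a range from 7000 nM to 60000 nM.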

Compound 3, half-maximal inhibitory concentration: 16600 nM
Estimate against measurement, compound 3: 1.2-fold (0.08 log units) above; low and high end bracket the measured number.
By their numbers in this assay, from the lowest: compounds 1, 3 and 2 (each within the scatter of the next).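

Among the compounds shown here, this is the first exchange of one substituted phenyl ring for another on a nitrogen on an aromatic ring, and in this assay replacing 3-chlorophenyl with 4-nitrophenyl gives a 1.2-fold lower number from compound 2 to compound 3 (0.08 log units; within the scatter). The change swaps a chlorine for a nitro group and moves the substituent's place on the phenyl ring, yet the step does not separate the two compounds; the comparison with the octyl compound, a 1.2-fold higher number from compound 1 to compound 3 (0.09 log units; within the scatter), does not separate those two either, so octyl, 3-chlorophenyl and 4-nitrophenyl on this nitrogen cannot be told apart on potency in this cell assay. No measured information is available to explain why these different groups give numbers that cannot be told apart.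

The compounds shown leave open whether a different kind of group on this nitrogen, such as a phenyl ring carrying a carboxylic acid or an amine, or a much shorter chain, would move the number beyond the scatter. The part of the molecule carrying the trifluoromethyl group is the same in all three compounds, so what it contributes to the cytotoxicity cannot be read from them.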